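This account rests on a few compounds, and the source may have more. Where it says the series, first, only, none or still open, it means among the compounds named here.

Measured so far:
- compound 1 `COc1cc(C)cc(-c2c(-c3ccnc(-c4ccc(C(C)=O)cc4)c3)cnn2CC#N)c1`, 78%
- compound 2 `COc1cc(C)cc(-c2nn(CC#N)cc2-c2ccnc(-c3ccc(N(C)C)cc3)c2)c1`, 98%

In a functional assay on SNB-75 cells (Homo sapiens) for cytotoxicity, read by sulforhodamine B assay, with a stated time of 48 h, tested at 0.01 uM (on this read-out lower numbers stand for a stronger effect and higher numbers for a weaker effect at the one concentration tested), compound 1 gives 78%, the lower of the two numbers shown. Compound 2 gives 98%, a higher number, and the gap between the two is beyond the usual scatter of this assay. Compound 2 is not a single-place neighbour of compound 1, so its value only shows what a dimethylamino-bearing compound on this core can read.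

Compound 3 `COc1cc(C)cc(-c2c(-c3ccnc(-c4ccc(N(C)C)cc4)c3)cnn2CC#N)c1` differs from compound 1 in one place: dimethylamino in place of acetyl on an aromatic carbon. Going by the values given here, no step between measured compounds covers this change directly. Since compound 2, which carries the same dimethylamino group on a related core, gives 98%, the expected step of a number 14 percentage points higher from compound 1 to compound 3 (beyond the scatter) is upward, towards weaker effect, and of moderate size. Compound 3 is therefore expected to read about 92%, within a range of 76% to 106%.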

Compound 3, a percentage reported as activity, at one concentration (the size of the read-out at that concentration, not a potency): 65%
Estimate against measurement, compound 3: 27 percentage points above; the measured number lies below the stated range.
By their numbers in this assay, from the lowest: compound 3; then compound 1; then compound 2.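

In this assay the change from 4-acetylphenyl to 4-(dimethylamino)phenyl gives a number 13 percentage points lower from compound 1 to compound 3 (beyond the scatter) and shows that this place on the shared core responds to the group it carries, with the dimethylamino compound giving the stronger effect. The group that leaves and the group that enters have the same count of heavy atoms and of hydrogen-bond acceptors, and neither has a ring or a net charge, so these counts do not separate the two groups. No evidence here explains the step.

On these data alone, whether a primary amine, a carboxylic acid or a longer alkyl chain at this place would read lower or higher remains open. As far as these compounds go, with a single step at this place, it is also open whether the same change would move the number in the same direction on another core.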